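Benzyl for 3-chlorophenyl on the aromatic nitrogen

A few compounds are considered here, and "the series" means these few. Any claim that something is new, unique, unknown or untested is made for them only; others in the source may bear on it.

Measured so far in a functional assay on NCI-H460 cells (Homo sapiens) for antiproliferative activity, read by CCK-8 assay, with a stated time of 72 h, tested at 2 uM; on this read-out higher numbers stand for a stronger effect at the one concentration tested and lower numbers for a weaker effect:
compound 1 `CN1CCN(c2nc(Cl)nc3c2ncn3Cc2ccc(C(=O)Nc3ccccc3N)cc2)CC1` gives 13.5%
compound 2 `Nc1ccccc1NC(=O)/C=C/c1ccc(Cn2cnc3c(Nc4cccc(Cl)c4)nc(Cl)nc32)cc1` gives 7.11%
compound 3 `CCCCn1cnc2c(Nc3ccccc3)nc(NCOCc3ccc(/C=C/C(=O)Nc4ccccc4N)cc3)nc21` gives 23.1%

Among the three numbers in this assay compound 2 stands lowest. Its nearest neighbour is compound 1, whose number sits within the usual scatter of that of compound 2, so the two cannot be ordered. Compound 3 stands beyond the scatter and higher than compound 2, and is the only one of the three that does.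

Compound 4 `Nc1ccccc1NC(=O)/C=C/c1ccc(Cn2cnc3c(NCc4ccccc4)nc(Cl)nc32)cc1` differs from compound 2 in one place: benzyl in place of 3-chlorophenyl on a nitrogen on an aromatic ring. For the measured compounds named here, the three measured compounds differ from one another at several places at once, so no single-change step between measured compounds is available to set the size of such a swap. With nothing to lean on, the expectation for this assay is a step of no more than the scatter, with no direction claimed; the measured step from compound 2 to compound 3 shows only that the series can move beyond the scatter when several changes are made together.

The step from compound 2 to compound 4 is expected to be a number 2.9 percentage points higher from compound 2 to compound 4 (within the scatter). Compound 4 is estimated at 10% in this assay, with a range from 0% to 24%.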

Compound 4, a percentage reported as inhibition, at one concentration (the size of the read-out at that concentration, not a potency): 4.62%
Estimate against measurement, compound 4: 5.4 percentage points above, and the stated range covers the measured number.
By their numbers in this assay, from the lowest: compounds 4, 2, 1 and 3 (each within the scatter of the next, the first and the last beyond it).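

In this assay, the series now has its first single-change step, a number 2.5 percentage points lower from compound 2 to compound 4 (within the scatter), so (3-chlorophenyl)amino to benzylamino on this nitrogen gives no change that can be told from the scatter. At this position, then, the chlorine-bearing aryl group can give way to benzyl, with its all-carbon make-up and matching heavy-atom count, and the number stays within the scatter. No measured property of these compounds bears on this step, so nothing can be said about what lies behind it.

Open, going by these compounds, is whether a longer chain on this nitrogen, such as phenethyl, or a ring carrying a carboxylic acid or an amine, would step beyond the scatter. Also open, on these data alone, is whether either swap would do so at a concentration other than the one tested.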